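The source may hold more compounds than are shown below. What is called first, only, known or untested is meant among the compounds shown, and "the series" means these compounds.

Compound 1 `CC[C@H](NC(=O)/C(C#N)=C/c1cccc(Br)n1)c1ccccc1` and compound 2 `N#C/C(=C\c1cccc(Br)n1)C(=O)N[C@H](c1ccccc1)C1CC1` share one core and differ only by ethyl in place of cyclopropyl on a saturated chain carbon bound to an amide-type nitrogen and an aromatic carbon. In a functional assay on MM1 cells (Homo sapiens) for antiproliferative activity, read by MTT assay, with a stated time of 72 h (a higher number here means a weaker inhibitor, a lower number a stronger inhibitor), compound 1 gives 1100 nM, and compound 2 gives 1400 nM; the step of a 1.3-fold lower number from compound 2 to compound 1 (0.10 log units; within the scatter) shows that this swap leaves potency essentially unchanged. Compound 3 `N#C/C(=C\c1ccc(-c2cccc([N+](=O)[O-])c2)o1)C(=O)NC(c1ccccc1)C1CC1` rests on a different core, and the difference between the two cores is not broken down here. In this assay compound 3 reaches only a limit of > 10000 nM, so no number is known for it. Compound 4 `CCC(NC(=O)/C(C#N)=C/c1ccc(-c2cccc([N+](=O)[O-])c2)o1)c1ccccc1` is made from compound 3 by the same change, (ethyl in place of cyclopropyl on a saturated chain carbon bound to an amide-type nitrogen and an aromatic carbon), at the same place. The step that the limit leaves unreadable from compound 3 to compound 4 is expected to be small because the earlier step of a 1.3-fold lower number from compound 2 to compound 1 (0.10 log units; within the scatter) was within the scatter. Since compound 3 already sits at the limit (the limit of > 10000 nM in this assay, at which 1 of the 3 values shown sits), compound 4 is expected to come out near 15000 nM, between 7000 nM and 40000 nM, most likely again reported as a limit rather than a number.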

Compound 4, half-maximal inhibitory concentration: > 10000 nM
Compound 4: a limit, no number; the forecaster's own chance of this, stated with the estimate: 70%; the middle value lies beyond the limit too.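

Compound 3 and compound 4 both give a limit, not a number, so the step between them cannot be read: the limit of > 10000 nM in this assay, at which 2 of the 4 values shown sit.

From the compounds shown here alone, whether ethyl in place of cyclopropyl changes potency on the core of compound 3 remains open.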